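Cytotoxicity of a pyrimidine ether series in MT4 cells

The source may hold more compounds than are shown below. What is called first, only, known or untested is meant among the compounds shown, and "the series" means these compounds.

Measured compounds:
compound 1 `CCCCCNc1cc(Oc2c(OC)cc3cc(C#N)ccc3c2OC)nc(Nc2ccc(C#N)cc2)n1` — > 125000 nM in an ADME assay on MT4 cells (Homo sapiens) for cytotoxicity, read by MTT assay, with a stated time of 5 days; on this read-out higher numbers stand for lower toxicity in this test and lower numbers for higher toxicity in this test
compound 2 `COc1cc2cc(C#N)ccc2c(OC)c1Oc1cc(NC2CCCC2)nc(Nc2ccc(C#N)cc2)n1` — > 125000 nM in this assay

In this assay compound 1 reaches only the limit of the test, > 125000 nM. Compound 2 likewise gives only a limit, > 125000 nM. Among the compounds with values here, the one step between them, a step that the two limits leave unreadable from compound 1 to compound 2, is therefore not readable in size, since both ends sit at the limit of > 125000 nM in this assay, at which 2 of the 2 values shown sit. Compound 2 thus stands at the limit, with no number to place it against compound 1.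

Compound 3 `COc1cc2cc(C#N)ccc2c(OC)c1Oc1cc(N2CCC(O)C2)nc(Nc2ccc(C#N)cc2)n1` is not yet measured. It differs from compound 2 in one place: 3-hydroxypyrrolidin-1-yl in place of cyclopentylamino on an aromatic carbon.

Within the data shown here, no measured step bears on this change in a readable way, because a step that the two limits leave unreadable from compound 1 to compound 2 is hidden by the two limits. Among the measured compounds shown here, the only guidance is that both compounds so far sit at the limit of > 125000 nM in this assay, at which 2 of the 2 values shown sit. Compound 3 is therefore expected to behave in the same way, with a step that the limit leaves unreadable from compound 2 to compound 3 that is expected to be none beyond the scatter, most likely reported again as a limit.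

Compound 3 is estimated at 150000 nM, with a range from 60000 nM to 400000 nM.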

Compound 3, half-maximal cytotoxic concentration: > 125000 nM
Compound 3 ended at the assay's limit; the forecaster's own chance of this, stated with the estimate: 80%; the middle value lies beyond the limit too.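

No step can be read between compound 1, compound 2 and compound 3, as each value is only a limit of the test: the limit of > 125000 nM in this assay, at which 3 of the 3 values shown sit.

The compounds shown leave open whether pentylamino, cyclopentylamino and 3-hydroxypyrrolidin-1-yl on the shared core differ at all in this assay, and at what concentration, if any, cytotoxicity would appear.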